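The source may hold more compounds than are shown below. What is called first, only, known or untested is meant among the compounds shown, and "the series" means these compounds.

In an assay for inhibition of HSP60/HSP10 (Homo sapiens), with a stated time of 60 min (on this read-out lower numbers stand for stronger inhibition and higher numbers for weaker inhibition), compound 1 `O=C(Nc1ccc(Sc2nc3ccccc3s2)c(Cl)c1)c1cc(Br)cc(Br)c1` reaches only the limit of > 100000 nM. Compound 2 `O=C(Nc1ccc(Sc2nc3ccccc3s2)c(Cl)c1)c1cc(Br)cc(Br)c1O` gives 4200 nM, the only number shown. The step of an at least 23-fold lower number from compound 1 to compound 2 (1.37 log units; beyond the scatter) is large; compound 1 sits at the limit, as the line the limit of > 100000 nM in this assay, at which 1 of the 2 values shown sits, states. Compound 3 `COc1ccccc1C(=O)Nc1ccc(Sc2nc3ccccc3s2)c(Cl)c1` is not yet measured; its change from compound 2 is 2-methoxyphenyl in place of 3,5-dibromo-2-hydroxyphenyl on a carbonyl carbon. For the measured compounds named here, this removes the hydroxy whose arrival carried the large step of an at least 23-fold lower number from compound 1 to compound 2 (1.37 log units; beyond the scatter), and it also removes both bromines, a change for which no measured step exists. On this basis compound 3 is expected to weaken markedly, by a step of a 12-fold higher number from compound 2 to compound 3 (1.08 log units; beyond the scatter) in this assay, with a real chance that only a limit is reported. The estimate for compound 3 is 50000 nM, within a range from 8000 nM to 300000 nM.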

Compound 3, half-maximal inhibitory concentration: > 100000 nM
Compound 3 was reported as a limit (the forecaster's own chance of this, stated with the estimate: 55%); middle value at least 2.0-fold (0.30 log units) from the limit.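

On the carbonyl carbon, 2-methoxyphenyl does not stand in for 3,5-dibromo-2-hydroxyphenyl: the change gives an at least 23-fold higher number from compound 2 to compound 3 (1.37 log units; beyond the scatter), a large step. Compound 3 is reported only as a limit, not as a number: the limit of > 100000 nM in this assay, at which 2 of the 3 values shown sit.

Compound 3 keeps an oxygen on the ring but has no hydrogen-bond donor and no bromine, while compound 1 keeps both bromines but lacks the hydroxy; among the compounds shown, only compound 2, with the hydroxy and the bromines together, gives a number, and the step between the two limits cannot be read.

Compound 3 loses the hydroxy and both bromines in a single change, and the compounds shown cannot separate these losses. Nor do they show whether an amine in place of the hydroxy, or chlorine in place of the bromines, would keep a measurable number.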